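Loss of a methoxy group on a bis-indolyl pyrazolone scaffold

A few compounds are considered here, and "the series" means these few. Any claim that something is new, unique, unknown or untested is made for them only; others in the source may bear on it.

The series rests on three measured compounds. Compound 1 `COc1ccc2[nH]c(-c3ccccc3)c(C(c3c(-c4ccccc4)[nH]c4ccc(Cl)cc34)C3C(=O)NN=C3C)c2c1` gives 1200 nM in a functional assay on HeLa cells (Homo sapiens) for cytotoxicity, read by MTT assay; on this read-out higher numbers stand for weaker inhibition and lower numbers for stronger inhibition. Compound 2 `CC1=NNC(=O)C1C(c1c(-c2ccccc2)[nH]c2ccccc12)c1c(-c2ccccc2)[nH]c2ccc(Cl)cc12` carries the change hydrogen in place of methoxy on an aromatic carbon relative to compound 1, and in this assay compound 2 gives 29800 nM; the step is a 25-fold higher number from compound 1 to compound 2 (1.40 log units; beyond the scatter). Compound 3 `COc1ccc2[nH]c(-c3ccccc3)c(C(c3c[nH]c4ccccc34)C3C(=O)NN=C3C)c2c1` gives 1700 nM in this assay, which places compound 3 within the scatter of compound 1 and well apart from compound 2. The difference between the core of compound 3 and the core of compound 1 is not broken down here.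

Compound 4 `CC1=NNC(=O)C1C(c1c[nH]c2ccccc12)c1c(-c2ccccc2)[nH]c2ccccc12` is not yet measured. Its relation to compound 3 is the change (hydrogen in place of methoxy on an aromatic carbon), the same change already seen between compound 1 and compound 2, at a place described in identical words. Because the earlier step was a 25-fold higher number from compound 1 to compound 2 (1.40 log units; beyond the scatter), a step of similar direction and size is expected for compound 4, namely a 15-fold higher number from compound 3 to compound 4 (1.17 log units; beyond the scatter), though the remaining parts of the two cores differ, so the expected size carries wide uncertainty. Compound 4 is therefore estimated at 25000 nM in this assay, with a plausible range from 6000 nM to 100000 nM.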

Compound 4, half-maximal inhibitory concentration: 7700 nM
For compound 4 the middle estimate is 3.2-fold (0.51 log units) above the measured one; measured number inside the range.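

Removing the methoxy group raises the number again in this assay, with the step reading a 4.5-fold higher number from compound 3 to compound 4 (0.66 log units; beyond the scatter). Going by these compounds alone, the direction of the change therefore carries from one core to the other in these two pairs, but its size does not, and the two steps differ by more than the scatter of such steps allows: the same change on two cores in this assay, a 25-fold higher number (1.40 log units; beyond the scatter) from compound 1 to compound 2 and a 4.5-fold higher number (0.66 log units; beyond the scatter) from compound 3 to compound 4, 5.5-fold (0.74 log units) apart, beyond the scatter of two such steps The result does not show which of the differences between the two cores sets the size of the step, and with only two pairs it gives no rule for predicting the step on a further core.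

On these data alone, only methoxy and hydrogen appear at this place on an aromatic carbon, so it remains open how a hydroxyl group, an ethoxy group or an amine would read there. As far as these compounds go, it also remains open whether the step on a third core would lie nearer the larger or the smaller of the two steps seen here.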